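Aryl urea exchange from compound 1 to compound 4

A few compounds are considered here, and "the series" means these few. Any claim that something is new, unique, unknown or untested is made for them only; others in the source may bear on it.

Measured compounds:
compound 1 `O=C(Nc1cccc(-n2cc(-c3ccncc3)c(-c3ccc(Cl)c(O)c3)n2)c1)Nc1cccc(C(F)(F)F)c1`: 1060 nM
compound 2 `COc1cc(-c2nn(-c3cccc(NC(=O)Nc4cc(C(F)(F)F)cc(C(F)(F)F)c4)c3)cc2-c2ccncc2)ccc1Cl`: 411 nM
compound 3 `COc1cc(-c2nn(-c3cccc(NC(=O)c4cccc(C(F)(F)F)c4)c3)cc2-c2ccncc2)ccc1Cl`: 1200 nM

In a functional assay on OVCAR-3 cells (Homo sapiens) for inhibition, read by sulforhodamine B assay, with a stated time of 48 h (a higher number here means a weaker inhibitor of growth, a lower number a stronger inhibitor of growth), compound 1 gives 1060 nM, the second highest of the three numbers. Compound 3 gives 1200 nM, which lies within the scatter of compound 1. Compound 2 gives 411 nM, a lower number than compound 1 and beyond the scatter. For the measured compounds named here, no two of the measured compounds differ in only one place, so no single-change step is available from them, and the gap between compound 1 and compound 2 spans several changes at once.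

Compound 4 `O=C(Nc1cccc(-n2cc(-c3ccncc3)c(-c3ccc(Cl)c(O)c3)n2)c1)Nc1ccc(Cl)c(Cl)c1` differs from compound 1 in one place: 3,4-dichlorophenyl in place of 3-(trifluoromethyl)phenyl on an amide-type nitrogen. Going by the values given here, with no measured step to lean on, the expectation for this exchange of one substituted phenyl for another on the urea nitrogen is a step of modest size in this assay, if any, and no direction can be fixed beyond the scatter. Compound 4 is therefore expected to give 900 nM, with a range of 350 nM to 2300 nM, which corresponds to an expected step of a 1.2-fold lower number from compound 1 to compound 4 (0.07 log units; within the scatter).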

Compound 4, concentration for 50% growth inhibition: 1050 nM
Beside the measured number, compound 4's estimate is 1.2-fold (0.07 log units) below it; the measured number falls inside the stated range.
By their numbers in this assay, from the lowest: compound 2; then compounds 4, 1 and 3 (each within the scatter of the next).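

For the compounds shown here, this is the first single-change step, and it isolates the aryl group on the urea's amide-type nitrogen, which the earlier compounds could not do because they differ in several places at once. In this assay, 3,4-dichlorophenyl in place of 3-(trifluoromethyl)phenyl gives a 1.0-fold lower number from compound 1 to compound 4 (0.00 log units; within the scatter), so this assay does not tell the two substituted phenyl groups apart at this position, even though the entering group swaps trifluoromethyl for two chlorines. No measurement here bears on why the two groups read alike.

Still open, from the compounds shown here alone, is whether a phenyl carrying a carboxylic acid or a primary amine, or a longer alkyl chain in place of the phenyl, would also read alike at this nitrogen. Also open, going by these compounds, is whether the same exchange would read alike on the core of compound 2.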